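Working notes on a urea series: compound 3 to compound 4

This account rests on a few compounds, and the source may have more. Where it says the series, first, only, none or still open, it means among the compounds named here.

Measured so far, in an assay on isolated protein for inhibition of Ephrin type-A receptor 2 (Homo sapiens), read by thermal shift assay, tested at 10 uM; a higher number here means that the compound stabilises the target more against heat, a lower number that the compound stabilises the target less:
Compound 1, `CC(C)(C)c1cc(NC(=O)Nc2cc(F)cc(F)c2)n(-c2ccc(Br)cc2)n1`, gives 1.3 degrees C.
Compound 2, `Cn1nc(-c2ccccc2)cc1NC(=O)Nc1cc(F)cc(F)c1`, gives 0.3 degrees C.
Compound 3, `CC(C)(C)c1cc(NC(=O)Nc2ccc(Cl)cc2)n(-c2ccc(C(F)(F)F)cc2)n1`, gives 0.6 degrees C.

Compound 3 stands as the second of three numbers in this assay; the nearest is compound 2 at 0.3 degrees C, a gap within the scatter, and the furthest is compound 1 at 1.3 degrees C, also within the scatter. Among the measured compounds shown here, all three numbers are small and no two of them are separated by more than the usual scatter of this assay, so no compound can be called the stronger stabiliser on this evidence.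

The next compound, compound 4, `CC(C)(C)c1cc(NC(=O)Nc2ccc(Cl)cc2)n(-c2ccc(NC(=O)C3CC3)cc2)n1`, differs from compound 3 in one place: (cyclopropylcarbonyl)amino in place of trifluoromethyl on an aromatic carbon. For the measured compounds named here, no step between two measured compounds covers a change of this kind, so the size of the step can only be guessed from the small spread of the three numbers so far.

The step of a number 0.20 degrees C higher from compound 3 to compound 4 (within the scatter) is expected to stay within the scatter, with no direction favoured. Compound 4 is therefore estimated at 0.8 degrees C, with a range from -0.5 degrees C to 2 degrees C.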

Compound 4, shift of the target's melting temperature: 3 degrees C
Compound 4: middle estimate off by 2.2 degrees C, on the low side; measured number above the stated range.
By their numbers in this assay, from the lowest: compounds 2, 3 and 1 (each within the scatter of the next); then compound 4.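

In this assay, among the compounds shown here, (cyclopropylcarbonyl)amino in place of trifluoromethyl on an aromatic carbon, para to a large group, gives a number 2.4 degrees C higher from compound 3 to compound 4 (beyond the scatter), the first step to be read beyond the scatter and a sign that the number responds to what stands at this position. The change is large in its make-up as well: the group that enters brings a three-membered ring, a double bond outside aromatic rings, a hydrogen-bond donor and a hydrogen-bond acceptor, none of which the trifluoromethyl group has, so this single step cannot assign the gain to any one of these features. Nothing measured here bears on why the number moves at this position.

Still open, on these data alone, is which part of the new group carries the step, the amide hydrogen, the carbonyl or the three-membered ring, and an acetamide, a plain amine or a carboxylic acid on the same aromatic carbon would begin to separate these parts. Also open, as far as these compounds go, is whether the same exchange gives a step of similar size when the chlorine on the other aromatic ring of the urea is replaced by another group, such as a methoxy group.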